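Adding Chloro to Compound 3: Expected Effect on Cytotoxicity

The compounds below may be only part of what the source reports. "The series", "measured", "known", "first", "only" and "open" are said of these compounds alone.

Compound 1 `CCN(CC)CN1C(=O)/C(=N/NC(=S)Nc2ccccc2)c2cc(Cl)ccc21`: 6900 nM
Compound 2 `CCN(CC)CN1C(=O)/C(=N/NC(N)=S)c2cc(Cl)ccc21`: > 100000 nM, a limit of the assay
Compound 3 `CCN(CC)CN1C(=O)/C(=N/NC(=S)Nc2ccc(OC)cc2)c2ccccc21`: 3500 nM

These three compounds were tested in an ADME assay on CRFK cells (Felis catus) for cytotoxicity; on this read-out higher numbers stand for lower toxicity in this test and lower numbers for higher toxicity in this test. Compound 3 has the lowest of the two numbers, with compound 1 the nearest, within the scatter. The value of compound 2 is a limit of the assay, not a number. For the measured compounds named here, the only measured step, an at least 14-fold higher number from compound 1 to compound 2 (1.16 log units; beyond the scatter), concerns the group on the amide-type nitrogen and does not bear on the change at hand. Compound 4 `CCN(CC)CN1C(=O)/C(=N/NC(=S)Nc2ccc(OC)cc2)c2cc(Cl)ccc21` differs from compound 3 by chloro in place of hydrogen on an aromatic carbon. Compound 1 already carries this chloro, and its number sits within the scatter of compound 3, so no step beyond the scatter is expected in this assay. Compound 4 is therefore estimated at 4000 nM, between 1500 nM and 12000 nM, an expected step of a 1.1-fold higher number from compound 3 to compound 4 (0.06 log units; within the scatter).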

Compound 4, half-maximal cytotoxic concentration: 3600 nM
The estimate for compound 4 lay 1.1-fold (0.05 log units) above the measured number, and the stated range covers the measured number.
By their numbers in this assay, from the lowest: compounds 3, 4 and 1 (each within the scatter of the next). At a limit, above all of these: compound 2.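

In this assay, chloro in place of hydrogen on an aromatic carbon can now be read directly, and it stays within the scatter (a 1.0-fold higher number from compound 3 to compound 4 (0.01 log units; within the scatter)). With chloro present, the added methoxy also stays within the scatter (a 1.9-fold lower number from compound 1 to compound 4 (0.28 log units; within the scatter)), whereas 4-methoxyphenyl in place of hydrogen on the amide-type nitrogen gives a large step (an at least 27-fold lower number from compound 2 to compound 4 (1.44 log units; beyond the scatter)). That large step starts from a limit for compound 2, not a number: the limit of > 100000 nM in this assay, at which 1 of the 4 values shown sits.

Going by these compounds, whether bromo, nitro or an amine at this aromatic carbon would also stay within the scatter remains open.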